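Lengthening the hydroxamate linker of a thienyl thiadiazole

A few compounds are considered here, and "the series" means these few. Any claim that something is new, unique, unknown or untested is made for them only; others in the source may bear on it.

Compounds 1 and 2 share a core with compound 3 and compound 4, and in a functional assay on K562 cells (Homo sapiens) for antiproliferative activity, read by MTT assay, with a stated time of 48 h (on this read-out lower numbers stand for stronger inhibition and higher numbers for weaker inhibition), they fall close together: compound 1 `O=C(CCCCCCC(=O)Nc1nnc(-c2cccnc2)s1)NO` gives 4360 nM, and compound 2 `O=C(CCCCCCC(=O)Nc1nnc(-c2ccncc2)s1)NO` gives 4150 nM, with a 1.1-fold lower number from compound 1 to compound 2 (0.02 log units; within the scatter) between them. Compound 3 `O=C(CCCCCC(=O)Nc1nnc(-c2cccs2)s1)NO` stands apart from these two: in this assay compound 3 reached only the limit > 60000 nM, so for compound 3 no number is known, only that it lies at the limit described by the limit of > 60000 nM in this assay, at which 1 of the 3 values shown sits.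

The step from compound 3 to compound 4 `O=C(CCCCCCC(=O)Nc1nnc(-c2cccs2)s1)NO` is (hydroxycarbamoyl)methyl in place of hydroxycarbamoyl on a saturated chain carbon, five bonds along the chain from a carbonyl carbon. Going by the values given here, none of the measured steps covers this change; the only measured step, from compound 1 to compound 2, concerns the aromatic group and was within the scatter, so it carries no information on the chain. What can be said is that compound 1 and compound 2 carry the longer chain that compound 4 also carries, and both give numbers rather than limits in this assay.

On that basis compound 4 is expected to give a number rather than a limit, estimated at 6000 nM with a range from 2000 nM to 30000 nM, which would mean an expected step of an at least 10-fold lower number from compound 3 to compound 4 (1.00 log units; beyond the scatter).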

Compound 4, half-maximal inhibitory concentration: 1560 nM
Beside the measured number, compound 4's estimate is 3.8-fold (0.59 log units) above it; the whole stated range lies above it.
By their numbers in this assay, from the lowest: compound 4; then compounds 2 and 1 (each within the scatter of the next). At a limit, above all of these: compound 3.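

In this assay, the chain now proves decisive in a single-place change: with thiophen-2-yl held fixed, (hydroxycarbamoyl)methyl in place of hydroxycarbamoyl on a saturated chain carbon, five bonds along the chain from a carbonyl carbon, gives an at least 38-fold lower number from compound 3 to compound 4 (1.58 log units; beyond the scatter). From the compounds shown here alone, compound 3 is held at a limit and not a number, so the full size of that step stays unknown: the limit of > 60000 nM in this assay, at which 1 of the 4 values shown sits. The aromatic group, on which the two pyridine compounds had shown nothing beyond the scatter, also turns out to count on the longer chain, though far less, since thiophen-2-yl in place of pyridin-4-yl gives a 2.7-fold lower number from compound 2 to compound 4 (0.42 log units; beyond the scatter) and thiophen-2-yl in place of pyridin-3-yl gives a 2.8-fold lower number from compound 1 to compound 4 (0.45 log units; beyond the scatter).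

The compounds shown leave open whether 2-(hydroxycarbamoyl)ethyl or 3-(hydroxycarbamoyl)propyl at this place would lower the number further or raise it again. Also open, going by these compounds, are whether the pyridin-3-yl and pyridin-4-yl groups would fare as thiophen-2-yl does on the shorter chain, and whether a carboxylic acid could stand in place of the hydroxycarbamoyl end.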